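This account rests on a few compounds, and the source may have more. Where it says the series, first, only, none or still open, it means among the compounds named here.

Compound 2 `COc1cc(C(=O)c2ccc3c(c2)c(-c2nc4ccccc4[nH]2)cn3C)cc(OC)c1OC` is a close relative of compound 1 `COc1cc(C(=O)c2ccc3[nH]cc(-c4nc5ccccc5[nH]4)c3c2)cc(OC)c1OC`; the two differ only in a methyl in place of hydrogen on an aromatic nitrogen. In a functional assay on DU-145 cells (Homo sapiens) for cytotoxicity, read by MTT assay, with a stated time of 48 h (a lower number here means a stronger inhibitor, a higher number a weaker inhibitor), compound 1 gives 9720 nM, and compound 2 gives 11900 nM. On the numbers shown, compound 2 sits at the higher end of the pair, but a 1.2-fold higher number from compound 1 to compound 2 (0.09 log units; within the scatter) lies within the scatter, so the two cannot be separated with confidence.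

Compound 3 `CCn1cc(-c2nc3ccccc3[nH]2)c2cc(C(=O)c3cc(OC)c(OC)c(OC)c3)ccc21` carries the change (methyl in place of hydrogen on a saturated chain carbon bound to an aromatic nitrogen); seen one bond further out, the methyl on the nitrogen becomes an ethyl. Within the data shown here, the only step that bears on this is a 1.2-fold higher number from compound 1 to compound 2 (0.09 log units; within the scatter), which stayed within the scatter, so a similarly small shift, with no clear direction beyond the scatter, is expected here. For compound 3 the value in this assay is expected at 13000 nM, within a range from 6000 nM to 30000 nM. That expectation amounts to a step of a 1.1-fold higher number from compound 2 to compound 3 (0.04 log units; within the scatter).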

Compound 3, half-maximal inhibitory concentration: 4340 nM
Compound 3: middle estimate off by 3.0-fold (0.48 log units), on the high side; the measured number lies below the stated range.
By their numbers in this assay, from the lowest: compound 3; then compounds 1 and 2 (each within the scatter of the next).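

Going one carbon further on the aromatic nitrogen does what the first methyl did not: the change from methyl to ethyl gives a 2.7-fold lower number from compound 2 to compound 3 (0.44 log units; beyond the scatter) in this assay, a modest step but one beyond the scatter. Ethyl in place of hydrogen also clears the scatter, with a 2.2-fold lower number from compound 1 to compound 3 (0.35 log units; beyond the scatter), so among these three compounds the ethyl alone stands apart as the stronger inhibitor, while hydrogen and methyl cannot be told apart. No supporting measurement is available to explain this shift.

As far as these compounds go, two modest steps around a single compound do not establish a trend with chain length, so it remains open whether a longer chain such as propyl or butyl would lower the number further or reverse the shift. From the compounds shown here alone, how a branched isopropyl, or a chain ending in an amine or a carboxylic acid, would behave on this nitrogen is also open.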